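Benzyloxy in place of isopentyloxy on the shared core

A few compounds are considered here, and "the series" means these few. Any claim that something is new, unique, unknown or untested is made for them only; others in the source may bear on it.

Measured compounds:
Compound 1 `CCCCOc1ccc(C(=O)Nc2cccc(C(=O)O)c2)cc1`: 105 nM
Compound 2 `CC(C)COc1ccc(C(=O)Nc2cccc(C(=O)O)c2)cc1`: 357 nM
Compound 3 `CC(C)CCOc1ccc(C(=O)Nc2cccc(C(=O)O)c2)cc1`: 215 nM

In an assay on isolated protein for agonist activity at Bile acid receptor (Homo sapiens), read by TR-FRET, with a stated time of 3 h, in the absence of a further agent (on this read-out higher numbers stand for an effect only at larger amounts of compound and lower numbers for an effect already at smaller amounts), compound 1 gives 105 nM, compound 2 gives 357 nM and compound 3 gives 215 nM. Compound 3 thus holds the second highest of the three numbers; it lies within the scatter of compound 2 and is separated from compound 1 by a step beyond the scatter, a 2.0-fold higher number from compound 1 to compound 3 (0.31 log units; beyond the scatter).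

Compound 4 `O=C(O)c1cccc(NC(=O)c2ccc(OCc3ccccc3)cc2)c1` differs from compound 3 by phenyl in place of isobutyl on a saturated chain carbon bound to an oxygen on an aromatic ring. All three measured steps concern the chain on this same oxygen: a 3.4-fold higher number from compound 1 to compound 2 (0.53 log units; beyond the scatter), a 2.0-fold higher number from compound 1 to compound 3 (0.31 log units; beyond the scatter) and a 1.7-fold lower number from compound 2 to compound 3 (0.22 log units; within the scatter). They show that rearranging or extending the saturated chain moves this assay only modestly and sometimes not beyond the scatter. For the measured compounds named here, none of them brings in a six-membered aromatic ring, so the change to compound 4 has no direct precedent among the measured compounds. On that basis compound 4 is expected to stay close to compound 3, with a step of a 1.1-fold lower number from compound 3 to compound 4 (0.03 log units; within the scatter) and no confident direction. Compound 4 is therefore estimated at 200 nM, within a range of 70 nM to 600 nM.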

Compound 4, half-maximal effective concentration: 135 nM
Beside the measured number, compound 4's estimate is 1.5-fold (0.17 log units) above it; the range from low to high includes it.
By their numbers in this assay, from the lowest: compounds 1, 4, 3 and 2 (each within the scatter of the next, the first and the last beyond it).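

In this assay, for the compounds shown here, the change to benzyloxy shows that a six-membered aromatic ring of carbon only can be carried on a saturated chain carbon bound to an oxygen on an aromatic ring, where the earlier compounds held only saturated chains. Against the isobutyl of compound 3 and the propyl of compound 1, the phenyl leaves the number within the scatter (a 1.6-fold lower number from compound 3 to compound 4 (0.20 log units; within the scatter)) (a 1.3-fold higher number from compound 1 to compound 4 (0.11 log units; within the scatter)), and only against the isopropyl of compound 2 does the step pass beyond it, modestly (a 2.6-fold lower number from compound 2 to compound 4 (0.42 log units; beyond the scatter)). No measurement is at hand that would explain these steps.

The compounds shown leave open whether this tolerance extends to a phenyl bearing a fluorine or a methoxy group, to a cyclohexyl group in its place, or to a pyridine ring, which would bring a ring nitrogen to this position. They also leave open whether a longer chain between the oxygen and the phenyl, as in phenethyloxy, would keep the number in the same range.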